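Octyl in place of propoxy on the benzimidazole side chain

The source may report more compounds than this note shows. Statements on the series, on what has been measured and on what is new or still open speak of the compounds shown alone.

Measured so far:
Compound 1 `CCCN1CCCN(c2nc3ccccc3n2CCOCC)CC1` gives 8.4 nM in a functional assay on ileum for inhibition of histamine H1 receptor (Cavia porcellus); a lower number here means a stronger inhibitor, a higher number a weaker inhibitor.
Compound 2 `CCCOCCn1c(N2CCN(C)CC2)nc2ccccc21` gives 20 nM in this assay.
Compound 3 `CCOCCn1c(N2CCCN(Cc3ccccc3)CC2)nc2ccccc21` gives 15 nM in this assay.

Compound 2 has the highest of the three numbers; its gap to compound 3 is within the scatter, while its gap to compound 1 lies beyond it. Compound 4 `CCCCCCCCCCn1c(N2CCN(C)CC2)nc2ccccc21` differs from compound 2 by octyl in place of propoxy on a saturated chain carbon, two bonds along the chain from an aromatic nitrogen. Among the measured compounds shown here, none of the measured steps bears on this change: the one step with a single difference, a 1.8-fold higher number from compound 1 to compound 3 (0.25 log units; within the scatter), concerns the amine side of the shared core and is within the scatter, and no compound varies the chain on the aromatic nitrogen in this way. The expectation for compound 4 in this assay therefore rests only on the shared core and the unchanged amine, and the step of a 1.5-fold higher number from compound 2 to compound 4 (0.18 log units; within the scatter) is estimated to be small, with a wide range in either direction. Compound 4 is expected to give 30 nM, between 8 nM and 120 nM.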

Compound 4, half-maximal inhibitory concentration: 4200 nM
Compound 4: middle estimate off by 140-fold (2.15 log units), on the low side, and the stated range ends below it.
By their numbers in this assay, from the lowest: compounds 1, 3 and 2 (each within the scatter of the next, the first and the last beyond it); then compound 4.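

In this assay, the side chain proves highly sensitive to this change: octyl in place of propoxy, on a saturated chain carbon, two bonds along the chain from an aromatic nitrogen, gives a 210-fold higher number from compound 2 to compound 4 (2.32 log units; beyond the scatter). Among the compounds shown here, the only earlier step, a 1.8-fold higher number from compound 1 to compound 3 (0.25 log units; within the scatter), concerned the amine side and showed nothing about this position. The exchange replaces 4 heavy atoms, including 1 hydrogen-bond acceptor, with 8 carbon atoms and no acceptor, so this single pair cannot separate chain size from the loss of the oxygen, and no measurement at hand explains the size of the step.

The compounds shown leave open how a butyl or hexyl group would read at this place, and whether a longer chain carrying an ether oxygen would stay close to compound 2. They also leave open whether octyl has a similar effect alongside the other amines in the series.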